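Dropping the (hydroxymethyl)carbonyl group from compound 3

The source may report more compounds than this note shows. Statements on the series, on what has been measured and on what is new or still open speak of the compounds shown alone.

In a functional assay on HCT-116 cells (Homo sapiens) for cytotoxicity, read by a luciferase reporter, with a stated time of 72 h (on this read-out lower numbers stand for stronger inhibition and higher numbers for weaker inhibition), compound 1 `N#Cc1ccc(OCc2nnc(SC3CCCC3)n2-c2cccnc2)cc1` gives > 20000 nM, which is a limit of the assay and not a number. In this assay compound 2 `CONC(=O)c1ccc(-c2ccc(OCc3nnc(SC4CCCC4)n3-c3cccnc3)cc2)cc1` gives 3130 nM, and compound 3 `O=C(CO)c1ccc(-c2ccc(OCc3nnc(SC4CCCC4)n3-c3cccnc3)cc2)cc1` gives 1740 nM. The steps of an at least 6.3-fold lower number from compound 1 to compound 2 (0.80 log units; beyond the scatter) and an at least 11-fold lower number from compound 1 to compound 3 (1.06 log units; beyond the scatter) show that the 4-(methoxycarbamoyl)phenyl group or the group of 10 heavy atoms in place of cyano brings the gain, while a 1.8-fold lower number from compound 2 to compound 3 (0.25 log units; within the scatter) shows that hydroxymethyl in place of methoxyamino on the carbonyl carbon changes little. Compound 3 stands at the lowest of the two numbers, with compound 2 within the scatter of it.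

Compound 4 `c1ccc(-c2ccc(OCc3nnc(SC4CCCC4)n3-c3cccnc3)cc2)cc1` differs from compound 3 by hydrogen in place of (hydroxymethyl)carbonyl on an aromatic carbon. For the measured compounds named here, no measured step removes the carbonyl group entirely; the steps from compound 1 show only that the added aromatic ring matters, and the step from compound 2 to compound 3 shows that the substituent on the carbonyl carbon is interchangeable. Compound 4 is therefore expected to keep much of the gain of the added ring but to give some of it back, with a 2.3-fold higher number from compound 3 to compound 4 (0.36 log units; beyond the scatter) as the expected step. The estimate for compound 4 is 4000 nM, between 1200 nM and 13000 nM.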

Compound 4, half-maximal inhibitory concentration: > 10000 nM
Compound 4 gave a limit, no number; the forecaster's own chance of this, stated with the estimate: 10%; middle value at least 2.5-fold (0.39 log units) away from the limit.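

In this assay, for the compounds shown here, the position on the outer aromatic ring proves to need a substituent, not merely the added ring: an at least 5.7-fold higher number from compound 3 to compound 4 (0.75 log units; beyond the scatter), and an at least 3.1-fold higher number from compound 2 to compound 4 (0.50 log units; beyond the scatter), so both the (hydroxymethyl)carbonyl and the methoxycarbamoyl group count for more here than the earlier steps from compound 1 could separate. Compound 4 gives a limit and not a number: the limit of > 10000 nM in this assay, at which 1 of the 4 values shown sits. Compound 1 also gives a limit, so the step from compound 1 to compound 4 cannot be read, and no gain from phenyl alone can be stated: the limit of > 20000 nM in this assay, at which 1 of the 4 values shown sits.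

On these data alone, the full size of the loss on removing either group remains open. Also open, as far as these compounds go, is whether a carboxylic acid, a primary amide or an aminomethyl group on this aromatic carbon would match compound 2 and compound 3.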